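This account rests on a few compounds, and the source may have more. Where it says the series, first, only, none or still open, it means among the compounds named here.

Compound 3, `Cc1ccc(Nc2ncc([C@H](NC(=O)c3nccs3)C3CCCC3)cc2Cl)cn1`, belongs to a set of three measured compounds that share one core and differ only in the saturated group on the chain carbon bound to the amide-type nitrogen and the aromatic carbon. In a functional assay on HEK293 cells for negative allosteric modulation of metabotropic glutamate receptor 5 (Homo sapiens), read by HTRF and inositol phosphate accumulation (on this read-out higher numbers stand for weaker inhibition and lower numbers for stronger inhibition), compound 3 gives 16.6 nM. Compound 1, `Cc1ccc(Nc2ncc([C@H](NC(=O)c3nccs3)C(C)(C)C)cc2Cl)cn1`, carries tert-butyl there and gives 30.9 nM in this assay, while compound 2, `Cc1ccc(Nc2ncc([C@H](NC(=O)c3nccs3)C3CC3)cc2Cl)cn1`, carries cyclopropyl and gives 9.7 nM. The number of compound 3 thus sits among its neighbours without being separated from either: a 1.9-fold lower number from compound 1 to compound 3 (0.27 log units; within the scatter), and a 1.7-fold higher number from compound 2 to compound 3 (0.23 log units; within the scatter). Among the measured compounds shown here, only the pair of compounds 1 and 2 is separated, with a 3.2-fold lower number from compound 1 to compound 2 (0.50 log units; beyond the scatter).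

Compound 4, `Cc1ccc(Nc2ncc([C@H](NC(=O)c3nccs3)C3CCCCC3)cc2Cl)cn1`, is the next member of this series. Its difference from compound 3 is cyclohexyl in place of cyclopentyl on a saturated chain carbon bound to an amide-type nitrogen and an aromatic carbon. For the measured compounds named here, the step most closely resembling it is the one from compound 2 to compound 3, where the saturated ring grew by two carbons and the number moved only within the scatter. A further growth of the ring by one carbon is therefore expected to give, at most, a small step in this assay, if anything towards a slightly higher number, as a 1.3-fold higher number from compound 3 to compound 4 (0.12 log units; within the scatter). Compound 4 is estimated to give 22 nM, within a range from 9 nM to 55 nM.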

Compound 4, half-maximal inhibitory concentration: 37.8 nM
For compound 4 the middle estimate is 1.7-fold (0.24 log units) below the measured one; the range from low to high includes it.
By their numbers in this assay, from the lowest: compounds 2, 3, 1 and 4 (each within the scatter of the next, the first and the last beyond it).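

In this assay, among the compounds shown here, the change from cyclopentyl to cyclohexyl is the first ring enlargement at this position to leave the scatter, with a 2.3-fold higher number from compound 3 to compound 4 (0.36 log units; beyond the scatter), whereas the step from cyclopropyl to cyclopentyl stayed within it. Taken across the three rings, the two ends of the size range are clearly separated, with a 3.9-fold higher number from compound 2 to compound 4 (0.59 log units; beyond the scatter), so this position does respond to ring size, although the cyclopentyl compound cannot be told apart from the cyclopropyl compound. The open-chain tert-butyl and the cyclohexyl ring give numbers that cannot be distinguished, with a 1.2-fold higher number from compound 1 to compound 4 (0.09 log units; within the scatter), and nothing available explains why this position responds as it does.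

The compounds shown leave open whether cyclobutyl would fall in line with the other rings and whether cycloheptyl would move the number further in the same direction. They also do not show how a ring carrying oxygen, such as tetrahydropyranyl, or an open chain such as isopropyl would behave on this saturated chain carbon.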